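Isopropyl for Acetyl: Little Change Expected from a Limit

The source may hold more compounds than are shown below. What is called first, only, known or untested is meant among the compounds shown, and "the series" means these compounds.

In a functional assay on the whole organism for inhibition, with Rattus norvegicus as the target (a lower number here means that less compound is needed, a higher number that more compound is needed for the effect), compound 2 `CC(=O)c1ccc(N/N=C2\CCC(C)n3c2ncc(C(=O)O)c3=O)cc1` reaches only a limit, > 100 umol/kg. Compound 1 `Cc1ccc(N/N=C2\CCC(C)n3c2ncc(C(=O)O)c3=O)cc1` likewise gives only a limit in this assay, namely > 1000 umol/kg. The step that the two limits leave unreadable from compound 1 to compound 2 cannot be read, as the limit of > 100 umol/kg in this assay, at which 1 of the 2 values shown sits, and the limit of > 1000 umol/kg in this assay, at which 1 of the 2 values shown sits, show. Compound 3 `CC(C)c1ccc(N/N=C2\CCC(C)n3c2ncc(C(=O)O)c3=O)cc1` differs from compound 2 by isopropyl in place of acetyl on an aromatic carbon. Going by the values given here, no measured step bears readably on this change; the single step available is unreadable. Compound 3 is expected to stay near the limit, with an estimated step that the limit leaves unreadable from compound 2 to compound 3 showing no direction beyond the scatter. Compound 3 is estimated at 300 umol/kg, ranging from 100 umol/kg to 3000 umol/kg.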

Compound 3, dose for 50% inhibition: > 100 umol/kg
Compound 3: a limit, no number; the forecaster's own chance of this, stated with the estimate: 85%; the middle value lies beyond the limit too.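

Compound 3, like compound 1 and compound 2, gives only a limit in this assay, so no step among these three compounds can be read. The compounds shown leave open how much of any of them is needed for the effect.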